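Adding a 4-methoxybenzyl group to an amidine scaffold

The source may report more compounds than this note shows. Statements on the series, on what has been measured and on what is new or still open speak of the compounds shown alone.

Measured compounds:
compound 1 `COc1ccc(Cn2nc(-c3ccccc3)c3cc(C(=N)Nc4cccc(C(F)(F)F)c4)nc(NC4CCCCC4)c32)cc1`: > 50000 nM
compound 2 `CN1CCN(c2ccc(NC(=N)c3cc4cn[nH]c4cn3)cc2)CC1`: 47500 nM
compound 3 `N=C(Nc1ccccc1)c1cc2cn[nH]c2cn1`: > 50000 nM

Among the measured compounds shown here, in a functional assay on MDA-MB-231 cells (Homo sapiens) for cytotoxicity, read by MTT assay, with a stated time of 72 h (a higher number here means a weaker inhibitor, a lower number a stronger inhibitor), compound 2 gives 47500 nM, the only actual number among the three results. For compound 1 the result is a limit of the assay rather than a number. For compound 3 the result is likewise a limit, and the limit of > 50000 nM in this assay, at which 2 of the 3 values shown sit, describes this floor. For the measured compounds named here, the one step with two measured ends, an at least 1.0-fold higher number from compound 2 to compound 3 (0.02 log units; that floor lies within the scatter), removes the 4-methylpiperazin-1-yl group and moves the result from a number onto the limit.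

Compound 4 `COc1ccc(Cn2ncc3cc(C(=N)Nc4ccc(N5CCN(C)CC5)cc4)ncc32)cc1` differs from compound 2 by 4-methoxybenzyl in place of hydrogen on an aromatic nitrogen. Going by the values given here, no measured step changes this aromatic nitrogen on its own: compound 1 carries the same 4-methoxybenzyl group, but it also differs from compound 2 in several other places, so its limit tells nothing specific about this one change. Among the compounds with values here, with no step bearing on it, the expected step of a 1.1-fold higher number from compound 2 to compound 4 (0.02 log units; within the scatter) is none beyond the scatter, and since compound 2 already sits close to the assay limit, compound 4 is expected to land near it too. The estimate for compound 4 in this assay is 50000 nM, with a range from 15000 nM to 150000 nM, and a fair chance that only a limit is reported.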

Compound 4, half-maximal inhibitory concentration: 5700 nM
Compound 4: middle estimate off by 8.8-fold (0.94 log units), on the high side; measured number below the stated range.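

In this assay, the aromatic nitrogen of the five-membered ring proves to be a place where a change can be seen: putting 4-methoxybenzyl in place of hydrogen there gives an 8.3-fold lower number from compound 2 to compound 4 (0.92 log units; beyond the scatter). The only earlier step with two measured ends concerned a different place, the 4-methylpiperazin-1-yl group, and it stayed within the scatter, so this is the first single change shown that clearly shifts the result. It also gives the series a compound whose result lies well clear of the limit of the assay, which most of the earlier results could not offer: the limit of > 50000 nM in this assay, at which 2 of the 4 values shown sit.

Going by these compounds, what remains open is which part of the 4-methoxybenzyl group matters, since a single pair cannot separate the methoxy group from the benzyl ring or show what a plain methyl or an unsubstituted benzyl group on the same nitrogen would do. The step also rests on one pair that carries the 4-methylpiperazin-1-yl group, so it leaves unknown whether the same change would lower the number on compound 3, which lacks that group.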